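Replacing the cyclohexyl tail of compound 3

The source may report more compounds than this note shows. Statements on the series, on what has been measured and on what is new or still open speak of the compounds shown alone.

Among the measured compounds shown here, compound 3 `CCOC(=O)[C@H]1CC[C@H](CNC(=O)c2ccc(Cc3cc4c(cc3C)C(C)(C)CCC4(C)C)o2)CC1` gives 51 nM in an assay on isolated protein for binding affinity to Gonadotropin-releasing hormone receptor (Homo sapiens) (on this read-out lower numbers stand for stronger inhibition and higher numbers for weaker inhibition), the second highest of the three numbers measured so far. Compound 1 `Cc1cc2c(cc1Cc1ccc(C(=O)NC[C@H]3CC[C@H](C(N)=O)CC3)o1)C(C)(C)CCC2(C)C` gives 13 nM, and compound 2 `Cc1cc2c(cc1Cc1ccc(C(=O)NC[C@H]3CC[C@H](C(=O)O)CC3)o1)C(C)(C)CCC2(C)C` gives 250 nM. These three differ only in the group on the carbonyl carbon of the cyclohexyl tail: a 19-fold higher number from compound 1 to compound 2 (1.28 log units; beyond the scatter), a 3.9-fold higher number from compound 1 to compound 3 (0.59 log units; beyond the scatter) and a 4.9-fold lower number from compound 2 to compound 3 (0.69 log units; beyond the scatter). The tail end therefore moves the number by modest to large amounts within this set.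

Compound 4 `Cc1cc2c(cc1Cc1ccc(C(=O)NCc3ccc(CN)cc3)o1)C(C)(C)CCC2(C)C` is not yet measured. Relative to compound 3 the change is 4-(aminomethyl)phenyl in place of 4-(ethoxycarbonyl)cyclohexyl on a saturated chain carbon bound to an amide-type nitrogen. For the measured compounds named here, none of the measured steps touches the ring itself; all three only exchange the substituent on its carbonyl carbon. Going by these compounds, nothing comparable to this change has been measured, and the direction remains open. The expectation for compound 4 is a number not far from that of compound 3, a 1.3-fold lower number from compound 3 to compound 4 (0.11 log units; within the scatter), but with a wide range. Compound 4 is estimated at 40 nM, expected to fall between 8 nM and 200 nM.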

Compound 4, inhibition constant: 140 nM
Compound 4: middle estimate off by 3.5-fold (0.54 log units), on the low side, and the stated range covers the measured number.
By their numbers in this assay, from the lowest: compound 1; then compound 3; then compounds 4 and 2 (each within the scatter of the next).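

In this assay, exchanging the whole 4-(ethoxycarbonyl)cyclohexyl for 4-(aminomethyl)phenyl gives a 2.7-fold higher number from compound 3 to compound 4 (0.44 log units; beyond the scatter), so the number at this position also moves when ring and end group are replaced together, not only when the substituent on the carbonyl carbon changes. Against the other two tails, the same kind of exchange reads an 11-fold higher number from compound 1 to compound 4 (1.03 log units; beyond the scatter) and a 1.8-fold lower number from compound 2 to compound 4 (0.25 log units; within the scatter), which leaves the 4-(aminomethyl)phenyl tail well short of 4-carbamoylcyclohexyl but within the scatter of 4-carboxycyclohexyl. Nothing available gives a measured reason for these steps.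

Ring and end group change together in compound 4, so the steps cannot be divided between them. A 4-(aminomethyl)cyclohexyl or a 4-carbamoylphenyl tail on the same chain carbon would separate the two.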